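The source may hold more compounds than are shown below. What is called first, only, known or untested is meant among the compounds shown, and "the series" means these compounds.

Measured compounds:
compound 1 `Cc1cccc(C2=NC(c3ccc(F)cc3)(c3ccc(F)cc3)CN2)c1` – 30 nM
compound 2 `Fc1ccc(C2(c3ccc(F)cc3)CNC(c3cccnc3)=N2)cc1` – 7.2 nM

Within the data shown here, in an assay on LM cells for displacement of a labelled ligand from Neuropeptide Y receptor type 5 (Homo sapiens) (on this read-out higher numbers stand for weaker inhibition and lower numbers for stronger inhibition), compound 2 gives the lowest of the two numbers, with a 4.2-fold lower number from compound 1 to compound 2 (0.62 log units; beyond the scatter) the only step at this position. Compound 3 `N#Cc1cccc(C2=NC(c3ccc(F)cc3)(c3ccc(F)cc3)CN2)n1` differs from compound 2 by 6-cyanopyridin-2-yl in place of pyridin-3-yl on a carbon with a double bond to nitrogen. Among the measured compounds shown here, the single measured step swaps a carbocyclic ring for pyridin-3-yl at the same carbon; no step covers a move of the ring nitrogen or an added nitrile, so the size of the change is unsure. A step of about a 2.1-fold higher number from compound 2 to compound 3 (0.32 log units; beyond the scatter) is expected, most likely within the scatter. Compound 3 is estimated at 15 nM, range 4 nM to 60 nM.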

Compound 3, half-maximal inhibitory concentration: 39 nM
Compound 3: middle estimate off by 2.6-fold (0.41 log units), on the low side; the range from low to high includes it.
By their numbers in this assay, from the lowest: compound 2; then compounds 1 and 3 (each within the scatter of the next).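

Having a ring nitrogen at this carbon does not by itself keep the lower number, as 6-cyanopyridin-2-yl gives a 5.4-fold higher number from compound 2 to compound 3 (0.73 log units; beyond the scatter) in this assay. The same group set against 3-methylphenyl gives a 1.3-fold higher number from compound 1 to compound 3 (0.11 log units; within the scatter), so these two groups cannot be told apart here, and the advantage lies with pyridin-3-yl alone among the three. No other data bear on the reason for this step.

The step moves the ring nitrogen and adds the nitrile together, leaving their separate shares open. Going by these compounds, how pyridin-2-yl without the nitrile, or pyridin-3-yl carrying a nitrile or an amine, would read also remains open.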